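Trimming a Phenyl Down to a Methyl

The source may report more compounds than this note shows. Statements on the series, on what has been measured and on what is new or still open speak of the compounds shown alone.

Compound 1 `COC(=O)c1ccc(-n2cc(CCCOS(=O)(=O)c3ccc(-c4ccccc4)cc3)nn2)cc1` is the starting point. In a functional assay on HepG2 cells (Homo sapiens) for cytotoxicity, read by MTT assay, with a stated time of 72 h (on this read-out higher numbers stand for weaker inhibition and lower numbers for stronger inhibition), compound 1 gives 46200 nM, and compound 2 `Cc1ccc(S(=O)(=O)OCCCc2cn(-c3cccc(F)c3)nn2)cc1` gives 61800 nM, a gap that stays within the usual scatter of the measurement. Compound 3 `Cc1ccc(-n2cc(CCCOS(=O)(=O)c3ccc(C)cc3)nn2)cc1` reaches only a limit of this assay, > 100000 nM. For the measured compounds named here, the one measured step, an at least 1.6-fold higher number from compound 2 to compound 3 (0.20 log units; that floor lies within the scatter), exchanges the group on the aromatic nitrogen and therefore does not touch the ring that is altered here.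

Compound 4 `COC(=O)c1ccc(-n2cc(CCCOS(=O)(=O)c3ccc(C)cc3)nn2)cc1` is compound 1 with a single change: methyl in place of phenyl on an aromatic carbon. Going by the values given here, no measured pair covers this exchange directly. What the numbers do show is that the two compounds carrying the methyl on that ring, compound 2 and compound 3, sit no lower than compound 1, and that one of the three values recorded sits at the limit of > 100000 nM in this assay, at which 1 of the 3 values shown sits. He therefore expects the number for compound 4 to rise rather than fall, by a modest step, a 1.7-fold higher number from compound 1 to compound 4 (0.24 log units; within the scatter), with a real chance that this assay returns only a limit. His estimate for compound 4 is 80000 nM, expected to lie between 35000 nM and 200000 nM.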

Compound 4, half-maximal inhibitory concentration: > 100000 nM
Compound 4 gave a limit, no number; the forecaster's own chance of this, stated with the estimate: 35%; middle value at least 1.2-fold (0.09 log units) away from the limit.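

The exchange of phenyl for methyl on an aromatic carbon, para to a large group, now has a direct reading in this assay: an at least 2.1-fold higher number from compound 1 to compound 4 (0.33 log units; beyond the scatter). Compounds 2 and 3 could not show this, as each differs from compound 1 in the group on the aromatic nitrogen as well as on this ring, whereas compound 1 and compound 4 share the methoxycarbonyl-bearing group there, so the step belongs to this position and this change alone. The step is only a floor, and the comparison of compound 3 with compound 4 cannot be read, since both compounds stand at the same limit and give no number, which now holds for more of the series: the limit of > 100000 nM in this assay, at which 2 of the 4 values shown sit.

The compounds shown leave open how much of the phenyl is needed, as nothing here tells whether a cyclohexyl, a pyridyl or a single chlorine at this position would stay with compound 1 or fall to the limit with compound 4. They also leave open whether the phenyl would give a comparable step on a compound carrying the 3-fluorophenyl of compound 2.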